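The source may hold more compounds than are shown below. What is called first, only, known or untested is meant among the compounds shown, and "the series" means these compounds.

Measured so far, in a functional assay for inhibition of sodium/hydrogen exchanger (Oryctolagus cuniculus); a lower number here means a stronger inhibitor, a higher number a weaker inhibitor:
- compound 1 `COc1cc(N2CCC(N)CC2)c(S(C)(=O)=O)cc1C(=O)N=C(N)N` gives 73 nM
- compound 2 `CS(=O)(=O)c1cc(C(=O)N=C(N)N)ccc1C1CCCCC1` gives 340 nM

Compound 2 holds the higher of the two numbers; its nearest neighbour is compound 1, whose number is lower by a margin beyond the scatter of this assay. The two structures differ in more than one place, so what separates them is not attributed to any single group.

Compound 3 `CS(=O)(=O)c1cc(C(=O)N=C(N)N)ccc1N1CCC(N)CC1` has not been measured. It is reached from compound 2 by a single change: 4-aminopiperidin-1-yl in place of cyclohexyl on an aromatic carbon. Among the measured compounds shown here, no measured pair shows this exact step. Compound 1, which carries the same 4-aminopiperidin-1-yl group, gives 73 nM in this assay, and that is the main guide. A step downward, beyond the scatter, is expected for a 3.1-fold lower number from compound 2 to compound 3 (0.49 log units; beyond the scatter). Compound 3 is therefore estimated at 110 nM in this assay, with a range from 35 nM to 350 nM.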

Compound 3, half-maximal inhibitory concentration: 160 nM
Estimate against measurement, compound 3: 1.5-fold (0.16 log units) below; the measured number falls inside the stated range.
By their numbers in this assay, from the lowest: compound 1; then compound 3; then compound 2.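

Putting 4-aminopiperidin-1-yl in place of cyclohexyl on the aromatic carbon ortho to a methylsulfonyl group gives a 2.1-fold lower number from compound 2 to compound 3 (0.33 log units; beyond the scatter) in this assay and so shows that this single change, on its own, lowers the number modestly. Among the compounds shown here, compound 3 also gives the first reading of the methoxy group, since hydrogen in place of methoxy gives a 2.2-fold higher number from compound 1 to compound 3 (0.34 log units; beyond the scatter) and so shows that compound 1, which carries methoxy, holds the lower number. No measurement shown accounts for either step.

The compounds shown leave open what the primary amine of 4-aminopiperidin-1-yl contributes, which a piperidin-1-yl or 4-hydroxypiperidin-1-yl group on the same carbon would test. They also leave open how ethoxy, chlorine or a methyl group would compare with methoxy on the shared core.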